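Replacing chloro with hydrogen on compound 1

This account rests on a few compounds, and the source may have more. Where it says the series, first, only, none or still open, it means among the compounds named here.

Measured so far in an ADME assay on liver for metabolic stability, with Liver microsome (Homo sapiens) as the target, read by LC-MS, using microsomes; a higher number here means faster removal of the compound, a lower number slower removal:
- compound 1 `O=C(NCc1cc(Cl)ccc1-n1cnnn1)[C@@H]1C[C@@H]2C[C@@H]2N1C(=O)[C@H](O)c1cccc(Cl)c1`: > 500 mL.min-1.g-1 (a limit)
- compound 2 `O=C(NCc1cc(Cl)ccc1-n1cnnn1)[C@@H]1CCON1C(=O)[C@H](O)c1ccccc1`: < 12 mL.min-1.g-1 (a limit)
- compound 3 `CC(C)(C)OC[C@@H](O)C(=O)N1C[C@@H]2C[C@@H]2[C@H]1C(=O)NCc1cc(Cl)ccc1-n1cnnn1`: 37 mL.min-1.g-1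

Compound 1 sits at the upper limit of this assay, and its reading of > 500 mL.min-1.g-1 is a limit and not a number. Compound 2 sits at the lower limit, and its reading of < 12 mL.min-1.g-1 is also a limit. Compound 3 is the only one of the three with a true number, at 37 mL.min-1.g-1.

Compound 4 `O=C(NCc1cc(Cl)ccc1-n1cnnn1)[C@@H]1C[C@@H]2C[C@@H]2N1C(=O)[C@H](O)c1ccccc1` keeps the core of compound 1 and has hydrogen in place of chloro on an aromatic carbon of a six-membered aromatic ring of carbon only, meta to a large group, so that 3-chlorophenyl becomes phenyl (hydrogen in place of chloro on an aromatic carbon). Within the data shown here, no measured pair isolates this change, and compound 2 differs from compound 4 in its core as well. Compound 2 nevertheless carries the same phenyl and shows < 12 mL.min-1.g-1, which is the only support for a downward expectation. An estimated at least 2.7-fold lower number from compound 1 to compound 4 (0.44 log units; beyond the scatter) is expected to be a fall beyond the usual scatter, though its true size cannot be fixed against a limit. Compound 4 is still expected to be cleared quickly, and a reading at the upper limit remains possible. For compound 4 the estimate is 180 mL.min-1.g-1, with an expected range from 60 mL.min-1.g-1 to 500 mL.min-1.g-1.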

Compound 4, intrinsic clearance in microsomes: < 16 mL.min-1.g-1
Compound 4: a limit, no number; the forecaster's own chance of this, stated with the estimate: 20%; at least 11-fold (1.05 log units) between middle value and limit.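

In this assay, the change from 3-chlorophenyl to phenyl on the core of compound 1 is now isolated as a single difference, and it gives an at least 31-fold lower number from compound 1 to compound 4 (1.49 log units; beyond the scatter); this one aromatic position therefore separates a compound at the top of the assay range from one at the bottom. Compound 4 gives < 16 mL.min-1.g-1, which is a limit of the assay and not a number. The printed step is only a minimum for the loss of this chloro, because the reading at the other end is also a limit: the limit of > 500 mL.min-1.g-1 in this assay, at which 1 of the 4 values shown sits.

As far as these compounds go, the step between compound 2 and compound 4 cannot be read, since both values are limits, so any contribution of the core to removal in the phenyl compounds stays unknown. From the compounds shown here alone, whether a fluoro, a methyl or a methoxy in place of the chloro on this ring would stay as low as hydrogen, or move back towards the reading of compound 1, remains open.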